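A few compounds are considered here, and "the series" means these few. Any claim that something is new, unique, unknown or untested is made for them only; others in the source may bear on it.

Three ureas on a shared core have numbers in a functional assay on NCI-H1581 cells (Homo sapiens) for inhibition, read by MTT assay, with a stated time of 48 h, tested at 10 uM; a higher number here means more inhibition at the concentration tested (going by the name of the read-out), a lower number less inhibition. Compound 1 `COc1cc(NC(=O)Nc2cc(Nc3ccc(OC)c(C)c3)ncn2)cc(OC)c1` gives 19.7%. Compound 2 `COc1cc(NC(=O)Nc2cc(Nc3ccc(C)c(F)c3)ncn2)cc(OC)c1` gives 38%, and compound 3 `COc1cc(NC(=O)Nc2cc(Nc3cccc(C(C)(C)C)c3)ncn2)cc(OC)c1` gives 35.1%. Compound 3 thus stands second highest of the three: the step of a number 2.9 percentage points lower from compound 2 to compound 3 (within the scatter) lies within the scatter, while the step of a number 15.4 percentage points higher from compound 1 to compound 3 (beyond the scatter) is beyond it, as is a number 18.3 percentage points higher from compound 1 to compound 2 (beyond the scatter).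

Compound 4 `COc1cc(NC(=O)Nc2cc(Nc3ccc(OC)c(I)c3)ncn2)cc(OC)c1` differs from compound 3 in one place: 3-iodo-4-methoxyphenyl in place of 3-(tert-butyl)phenyl on a nitrogen on an aromatic ring. Among the compounds with values here, the entering group, like the 4-methoxy-3-methylphenyl of compound 1, carries a methoxy, with iodine in place of that group's methyl, so the measured step that bears most on this change is the one between compound 1 and compound 3, run backwards: a number 15.4 percentage points higher from compound 1 to compound 3 (beyond the scatter). Within the data shown here, no measured step compares iodine with methyl on this ring, and the step of a number 2.9 percentage points lower from compound 2 to compound 3 (within the scatter) only shows that two groups without methoxy sit together within the scatter. The expectation is therefore a fall in this assay, of roughly the gap back toward compound 1, with the iodine leaving the size uncertain. Compound 4 is expected at 25%, between 10% and 42%. This estimate means a step of a number 10.1 percentage points lower from compound 3 to compound 4 (beyond the scatter), expected because the reverse of a number 15.4 percentage points higher from compound 1 to compound 3 (beyond the scatter) is the closest measured guide.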

Compound 4, a percentage reported as inhibition, at one concentration (the size of the read-out at that concentration, not a potency): 43%
Beside the measured number, compound 4's estimate is 18 percentage points below it, outside the stated range (above it).
By their numbers in this assay, from the lowest: compound 1; then compounds 3, 2 and 4 (each within the scatter of the next).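

In this assay, the pair compound 1 and compound 4 isolates a single change on the aniline ring, iodo in place of methyl on an aromatic carbon with the methoxy kept, and gives a number 23.3 percentage points higher from compound 1 to compound 4 (beyond the scatter); the methoxy-bearing ring therefore does not by itself go with the low number of compound 1, and the earlier reading of that ring as the weak feature no longer holds. Compound 4 also joins the upper group, with a number 7.9 percentage points higher from compound 3 to compound 4 (within the scatter) and a number 5 percentage points higher from compound 2 to compound 4 (within the scatter), so 3-iodo-4-methoxyphenyl, 3-(tert-butyl)phenyl and 3-fluoro-4-methylphenyl on this nitrogen cannot be ordered among themselves, and compound 1 alone stands apart from the other three. No measurement here bears on why iodo and methyl differ at this place.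

From the compounds shown here alone, whether the step belongs to iodine alone or extends to a bromo or chloro group in the same place remains open, as does the effect of replacing the methoxy of compound 4 with a hydroxyl or an amine. Going by these compounds, all of these numbers come from one concentration, so how the upper three compare in potency also remains open.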